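Lengthening the Link Between Amide and Chlorophenyl Ring

This account rests on a few compounds, and the source may have more. Where it says the series, first, only, none or still open, it means among the compounds named here.

Of the compounds shown here, three have been measured in a functional assay on CHO cells for antagonist activity at transient receptor potential cation channel subfamily V member 1 (Rattus norvegicus); on this read-out higher numbers stand for weaker inhibition and lower numbers for stronger inhibition. Compound 1 `COc1cc(C2(C(=O)NCc3ccc(C(C)(C)C)cc3)CC2)ccc1NS(C)(=O)=O` gives 2250 nM, compound 2 `CC(C(=O)NCc1ccc(Cl)cc1)c1ccc(NS(C)(=O)=O)c(F)c1` gives 367 nM, and compound 3 `Cc1ccc(/C=C/CNC(=O)C(C)c2ccc(NS(C)(=O)=O)c(F)c2)cc1C` gives 153 nM. Compound 2 thus stands second highest of the three numbers: its value lies beyond the scatter from both neighbours, with compound 3 the closer of the two and compound 1 the further.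

The step to compound 4 `CC(C(=O)NCCCc1ccc(Cl)cc1)c1ccc(NS(C)(=O)=O)c(F)c1` changes only the group on a saturated chain carbon bound to an amide-type nitrogen, where (2-(4-chlorophenyl)ethyl in place of 4-chlorophenyl on a saturated chain carbon bound to an amide-type nitrogen). In effect the 4-chlorophenyl ring is pushed further from the amide by two more saturated carbons, while everything else in compound 2 is kept.

For the measured compounds named here, no measured pair shows this exact change, so the expectation rests on compound 2 itself and on compound 3, whose longer link between amide and ring gives 153 nM. A step of roughly a 1.1-fold higher number from compound 2 to compound 4 (0.04 log units; within the scatter) is therefore expected, most likely none beyond the scatter. Compound 4 is expected to give about 400 nM, within a range from 120 nM to 1500 nM in this assay.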

Compound 4, inhibition constant: 135 nM
Estimate against measurement, compound 4: 3.0-fold (0.47 log units) above; the measured number falls inside the stated range.
By their numbers in this assay, from the lowest: compounds 4 and 3 (each within the scatter of the next); then compound 2; then compound 1.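

In this assay, putting 2-(4-chlorophenyl)ethyl in place of 4-chlorophenyl on a saturated chain carbon bound to an amide-type nitrogen brings a 2.7-fold lower number from compound 2 to compound 4 (0.43 log units; beyond the scatter) and this modest step lies beyond the scatter. The position therefore accepts the larger group, and carrying the same chlorinated ring further from the amide goes with stronger inhibition rather than a loss. Nothing measured here explains this gain, so it stands as an observation only.

On these data alone, only these two groups can be compared directly at this position, so it remains open whether a longer chain, or a chain carrying an amine, would lower the number further. As far as these compounds go, it is also open whether the chlorine matters on the lengthened chain, for instance compared with a trifluoromethyl group in its place.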